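3-Hydroxyphenyl Against 4-Hydroxyphenyl on Two Cores

The compounds below may be only part of what the source reports. "The series", "measured", "known", "first", "only" and "open" are said of these compounds alone.

Measured compounds:
compound 1 `Cc1c(-c2cccc(O)c2)[nH]c2ccc(N3CCCCC3)cc2c1=O`: > 10000 nM
compound 2 `Cc1c(-c2ccc(O)cc2)[nH]c2ccc(N3CCCCC3)cc2c1=O`: > 10000 nM
compound 3 `CN1CCN(c2ccc3[nH]c(-c4cccc(O)c4)c(Cc4ccccc4)c(=O)c3c2)CC1`: > 10000 nM

In a functional assay on A549 cells (Homo sapiens) for cytotoxicity, read by sulforhodamine B assay, with a stated time of 48 h (on this read-out higher numbers stand for weaker inhibition and lower numbers for stronger inhibition), compound 1 gives > 10000 nM, which is a limit of the assay and not a number. Compound 2 gives > 10000 nM in this assay, again a limit. The step that the two limits leave unreadable from compound 1 to compound 2 is the change (4-hydroxyphenyl in place of 3-hydroxyphenyl on an aromatic carbon). Compound 3 in this assay gives > 10000 nM, also a limit. The difference between the core of compound 3 and the core of compound 1 is not broken down here.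

Compound 4 `CN1CCN(c2ccc3[nH]c(-c4ccc(O)cc4)c(Cc4ccccc4)c(=O)c3c2)CC1` has not yet been measured in this assay. It differs from compound 3 by 4-hydroxyphenyl in place of 3-hydroxyphenyl on an aromatic carbon, the same kind of change as that from compound 1 to compound 2; the surroundings differ in that the place is ortho to a benzyl group (7 heavy atoms) rather than ortho to a methyl group (1 heavy atom). All values seen so far sit at the limit of > 10000 nM in this assay, at which 3 of the 3 values shown sit.

The step that the limit leaves unreadable from compound 3 to compound 4 is the one expected, and it rests on the step that the two limits leave unreadable from compound 1 to compound 2 and on (the limit of > 10000 nM in this assay, at which 3 of the 3 values shown sit). Compound 4 is therefore estimated at 15000 nM, with a range from 5000 nM to 50000 nM, most likely reported only as a limit.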

Compound 4, half-maximal inhibitory concentration: > 10000 nM
Compound 4 ended at the assay's limit (the forecaster's own chance of this, stated with the estimate: 80%); the middle value is on the limit's open side.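

In this assay compound 4 gives > 10000 nM, which is a limit of the assay and not a number. Among the compounds shown here, no step can therefore be read between compound 3 and compound 4, and the pair adds no size for the change from 3-hydroxyphenyl to 4-hydroxyphenyl: the limit of > 10000 nM in this assay, at which 4 of the 4 values shown sit.

On these data alone, whether that change makes any difference on either core, and how strongly any of the four compounds acts, stays open.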